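Branching the Hydroxy Acid Side Chain of Compound 3

The compounds below may be only part of what the source reports. "The series", "measured", "known", "first", "only" and "open" are said of these compounds alone.

Measured compounds:
compound 1 `CC(C)(C)[C@@H](O)C(=O)N1[C@@H]2C[C@@H]2C[C@H]1C(=O)NCc1cc(Cl)ccc1-n1cnnn1`: 1100 nM
compound 2 `O=C(NCc1cc(Cl)ccc1-n1cnnn1)[C@@H]1[C@H]2C[C@H]2CN1C(=O)[C@H](O)CC1CC1`: 1400 nM
compound 3 `CCCC[C@@H](O)C(=O)N1N=CC[C@H]1C(=O)NCc1cc(Cl)ccc1-n1cnnn1`: 610 nM

In a functional assay on a cell-free system (plasma, Homo sapiens), with a stated time of 3 min (a higher number here means a weaker inhibitor, a lower number a stronger inhibitor), compound 3 gives 610 nM, the lowest of the three numbers. Compound 1 gives 1100 nM, a gap that lies within the scatter, so the two cannot be ranked. Compound 2 gives 1400 nM, a gap that lies beyond the scatter. Compound 3 therefore sits at the favourable end without being clearly set apart from compound 1.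

Compound 4 `CC1(C[C@@H](O)C(=O)N2N=CC[C@H]2C(=O)NCc2cc(Cl)ccc2-n2cnnn2)CC1` keeps the core of compound 3 and changes only the side chain of the hydroxy acid: 1-methylcyclopropyl in place of propyl on a saturated chain carbon, two bonds along the chain from a carbonyl carbon and an oxygen on a saturated carbon. Among the measured compounds shown here, no measured pair shows what such a change does here; compound 1 and compound 2 carry branched groups on a different core and give no direct guide. The change is small in size and adds no donors, acceptors or charge, so the expected step of a 1.0-fold lower number from compound 3 to compound 4 (0.01 log units; within the scatter) is none beyond the scatter. Compound 4 is estimated at 600 nM, within a range from 250 nM to 1500 nM.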

Compound 4, half-maximal inhibitory concentration: 730 nM
The estimate for compound 4 lay 1.2-fold (0.09 log units) below the measured number; measured number inside the range.
By their numbers in this assay, from the lowest: compounds 3, 4, 1 and 2 (each within the scatter of the next, the first and the last beyond it).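

In this assay, among the compounds shown here, the change from propyl to 1-methylcyclopropyl on a saturated chain carbon gives a 1.2-fold higher number from compound 3 to compound 4 (0.08 log units; within the scatter) and this is the first step measured at this position on the shared core. It shows that a side chain carrying a three-membered ring can stand here in place of the open propyl group without a difference that can be told from the scatter of repeated measurements. Nothing measured here accounts for why the two side chains read so alike.

The compounds shown leave open whether an amine, a carboxylic acid or a much longer chain at this position would move the number beyond the scatter. They also leave open whether the same change would read alike on the core of compound 1.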